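Halogen swap on the fused ring: chloro to fluoro

A few compounds are considered here, and "the series" means these few. Any claim that something is new, unique, unknown or untested is made for them only; others in the source may bear on it.

Two measured analogues anchor the series. Compound 1 `Cc1cc2nc(-c3cccc(Oc4ccccc4)c3)cc(-c3ccccc3)c2cc1C` in a functional assay on G-361 cells (Homo sapiens) for inhibition, read by MTT assay, with a stated time of 24 h (a lower number here means a stronger inhibitor, a higher number a weaker inhibitor), gives 5840 nM. Compound 2 `Clc1ccc2nc(-c3cccc(Oc4ccccc4)c3)cc(-c3ccccc3)c2c1` gives 12000 nM in this assay, the highest of the two numbers; compound 1 sits below it by a margin beyond the usual scatter. These two differ in more than one place, so only the two values themselves are compared here.

Compound 3 `Fc1ccc2nc(-c3cccc(Oc4ccccc4)c3)cc(-c3ccccc3)c2c1` is not yet measured. It departs from compound 2 by a single change: fluoro in place of chloro on an aromatic carbon. Among the measured compounds shown here, no measured pair shows this change, so there is no step to lean on. Given the value of compound 2 at 12000 nM, and with the change exchanging one heavy atom for one heavy atom, no step beyond the scatter is expected in this assay in either direction. Compound 3 is estimated at 11000 nM, with a range of 4500 nM to 27000 nM. The expected step is a 1.1-fold lower number from compound 2 to compound 3 (0.04 log units; within the scatter).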

Compound 3, half-maximal inhibitory concentration: 3850 nM
Estimate against measurement, compound 3: 2.9-fold (0.46 log units) above; the measured number lies below the stated range.
By their numbers in this assay, from the lowest: compounds 3 and 1 (each within the scatter of the next); then compound 2.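

At the aromatic carbon meta to a fused ring and para to a fused ring, the choice of halogen registers in this assay: fluoro in place of chloro gives a 3.1-fold lower number from compound 2 to compound 3 (0.49 log units; beyond the scatter), even though the change exchanges one heavy atom for one heavy atom and involves no hydrogen-bond donors or acceptors. Among the compounds shown here, as the only pair here that differs in one place, it shows that this position responds to a single-atom change, which the two earlier values could not show. No measurement shown here accounts for the step.

Going by these compounds, it remains open whether the trend extends beyond these two halogens, for example to bromo, methoxy, an amine or a nitrile at this position. On these data alone, a single methyl at this position also remains untested, so the contribution of either methyl group in compound 1 cannot be separated.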